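The source may report more compounds than this note shows. Statements on the series, on what has been measured and on what is new or still open speak of the compounds shown alone.

Measured in an ADME assay on a cell-free system (plasma, Homo sapiens) for metabolic stability; on this read-out higher numbers stand for a longer-lived compound and lower numbers for a shorter-lived compound:
compound 1 `CS(=O)(=O)N(COC(=O)c1ccccc1)c1ccc([N+](=O)[O-])cc1Oc1ccccc1`, 0.0322 h;
compound 2 `CC(C)(C)C(=O)OCN(c1ccc([N+](=O)[O-])cc1Oc1ccccc1)S(C)(=O)=O`, 1.7 h;
compound 3 `Cc1cc(C)nc(N(COC(=O)c2ccccc2)S(=O)(=O)c2ccc(N)cc2)n1`, 0.69 h.

Compound 1 and compound 2 differ in one place only, (tert-butyl in place of phenyl on a carbonyl carbon), and the change gave a 53-fold higher number from compound 1 to compound 2 (1.72 log units; beyond the scatter). Compound 4 `Cc1cc(C)nc(N(COC(=O)C(C)(C)C)S(=O)(=O)c2ccc(N)cc2)n1` is not yet measured in this assay; against compound 3 it carries tert-butyl in place of phenyl on a carbonyl carbon, the place reading the same word for word, so this is the same change on a second core. The difference between the core of compound 1 and the core of compound 3 is not broken down here. Among the measured values compound 3 stands second, nearest to compound 2 and furthest from compound 1. Among the measured compounds shown here, for compound 4 a large step is expected, a 17-fold higher number from compound 3 to compound 4 (1.24 log units; beyond the scatter), resting on compound 1 to compound 2 because a 53-fold higher number from compound 1 to compound 2 (1.72 log units; beyond the scatter), tempered since only one such pair exists and the cores differ. The value of compound 4 is estimated at 12 h, between 3 h and 40 h.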

Compound 4, half-life: 4.07 h
The estimate for compound 4 lay 2.9-fold (0.47 log units) above the measured number, within the range that was stated.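

In this assay, tert-butyl in place of phenyl on a carbonyl carbon gives a 5.9-fold higher number from compound 3 to compound 4 (0.77 log units; beyond the scatter), the same direction as on the core of compound 1. The direction carries over to the second core, but the size of the step does not: the same change on two cores in this assay, a 53-fold higher number (1.72 log units; beyond the scatter) from compound 1 to compound 2 and a 5.9-fold higher number (0.77 log units; beyond the scatter) from compound 3 to compound 4, 9.0-fold (0.95 log units) apart, beyond the scatter of two such steps. Two pairs do not show which part of the cores sets the size of the step, nor whether the direction would hold on a further core.

Open, as far as these compounds go, is whether a longer chain or isopropyl on the carbonyl carbon would fall in the same direction as tert-butyl. Also open, from the compounds shown here alone, is how the change reads on a core carrying a carboxylic acid or a second amine.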